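Propylsulfanyl for Cyclopropylmethoxy: Expected Cytotoxicity of Compound 4

A few compounds are considered here, and "the series" means these few. Any claim that something is new, unique, unknown or untested is made for them only; others in the source may bear on it.

Compound 1, `CCCOc1nc(N)nc2c1ncn2/C=C1/C[C@@H]1CO`: 69400 nM
Compound 2, `Nc1nc(NC2CC2)c2ncn(/C=C3/C[C@@H]3CO)c2n1`: 213000 nM
Compound 3, `Nc1nc(OCC2CC2)c2ncn(/C=C3/C[C@@H]3CO)c2n1`: 112000 nM

Of the compounds shown here, three sharing one core have been tested in a functional assay on HFF cells (Homo sapiens) for cytotoxicity; on this read-out lower numbers stand for higher toxicity in this test and higher numbers for lower toxicity in this test. Compound 3 gives the second highest of the three numbers, but its steps to both neighbours stay within the scatter: the nearest is compound 1, with a 1.6-fold higher number from compound 1 to compound 3 (0.21 log units; within the scatter), and the furthest is compound 2, with a 1.9-fold lower number from compound 2 to compound 3 (0.28 log units; within the scatter). Among the compounds with values here, the only step beyond the scatter is a 3.1-fold higher number from compound 1 to compound 2 (0.49 log units; beyond the scatter), which is modest.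

Compound 4, `CCCSc1nc(N)nc2c1ncn2/C=C1/C[C@@H]1CO`, is yet to be measured. Its change from compound 3 is propylsulfanyl in place of cyclopropylmethoxy on an aromatic carbon. Within the data shown here, two measured steps bear on it. The step of a 1.6-fold higher number from compound 1 to compound 3 (0.21 log units; within the scatter) shows that changing the chain on the ether side moves the number little. The step of a 1.9-fold lower number from compound 2 to compound 3 (0.28 log units; within the scatter) shows that exchanging the linking group also stays within the scatter. Among the measured compounds shown here, no measured pair exchanges oxygen for sulfur, so that part of the change is untested. On this evidence the expected step is a 1.2-fold lower number from compound 3 to compound 4 (0.09 log units; within the scatter), not beyond the scatter. Compound 4 is therefore estimated at 90000 nM, with a range from 40000 nM to 200000 nM.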

Compound 4, half-maximal cytotoxic concentration: 283000 nM
Estimate against measurement, compound 4: 3.1-fold (0.50 log units) below, and the stated range ends below it.
By their numbers in this assay, from the lowest: compounds 1, 3, 2 and 4 (each within the scatter of the next, the first and the last beyond it).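

In this assay, the exchange of propoxy for propylsulfanyl with the three-carbon chain kept gives a 4.1-fold higher number from compound 1 to compound 4 (0.61 log units; beyond the scatter), the first measured replacement of the linking oxygen by sulfur at this position, and it lies beyond the scatter. Replacing cyclopropylmethoxy with propylsulfanyl gives a 2.5-fold higher number from compound 3 to compound 4 (0.40 log units; beyond the scatter), also beyond the scatter, although this step removes the three-membered ring as well as changing the linking atom, whereas replacing cyclopropylamino with propylsulfanyl gives a 1.3-fold higher number from compound 2 to compound 4 (0.12 log units; within the scatter), which is within the scatter and leaves those two groups undistinguished. Nothing available explains these shifts. The compounds shown leave open whether a cyclopropylmethylsulfanyl group or a longer chain on sulfur would give a similar number. They also leave open how a propylamino group at this position would compare.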